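Aryl variation on a shared tricyclic core, antiproliferative read-out

The source may hold more compounds than are shown below. What is called first, only, known or untested is meant among the compounds shown, and "the series" means these compounds.

Measured so far:
compound 1 `CCC1=C(O)c2c(oc(-c3ccc(C(F)(F)F)cc3)cc2=O)C(CC)(CC)C1=O`: 35.7 uM
compound 2 `CCC1=C(O)c2c(oc(-c3ccccc3OC)cc2=O)C(CC)(CC)C1=O`: 40.8 uM
compound 3 `CCC1=C(O)c2c(oc(-c3ccc(OC)c(OC)c3OC)cc2=O)C(CC)(CC)C1=O`: 9.4 uM

In a functional assay on KB cells (Homo sapiens) for antiproliferative activity, read by sulforhodamine B assay, with a stated time of 3 days (on this read-out higher numbers stand for an effect only at larger amounts of compound and lower numbers for an effect already at smaller amounts), compound 2 gives 40.8 uM, the highest of the three numbers. Compound 1 sits within the scatter of it, at 35.7 uM. Compound 3 stands apart, giving 9.4 uM, a number beyond the scatter below that of compound 2. For the measured compounds named here, no step between measured compounds differs in a single place, so nothing directly comparable to the change at hand is on record.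

Compound 4 `CCC1=C(O)c2c(oc(-c3cccc(C)c3C)cc2=O)C(CC)(CC)C1=O` is not yet measured. It differs from compound 2 as follows: 2,3-dimethylphenyl in place of 2-methoxyphenyl on an aromatic carbon

The three measured numbers give no guide to what a methyl-substituted aryl group does here; compound 3, the only one beyond the scatter, carries three methoxy groups rather than none. For compound 4 the expectation is therefore a step of a 1.4-fold lower number from compound 2 to compound 4 (0.13 log units; within the scatter) in this assay, within the scatter of compound 2. Compound 4 is estimated at 30 uM, with a range from 10 uM to 90 uM.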

Compound 4, concentration for half-maximal effect: 3.1 uM
Compound 4: the middle estimate sits 9.7-fold (0.99 log units) above what was measured; measured number outside the range, below it.
By their numbers in this assay, from the lowest: compound 4; then compound 3; then compounds 1 and 2 (each within the scatter of the next).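

In this assay, 2,3-dimethylphenyl in place of 2-methoxyphenyl on the aromatic carbon next to the ring oxygen gives a 13-fold lower number from compound 2 to compound 4 (1.12 log units; beyond the scatter). For the compounds shown here, this is the first single-place comparison, and it shows that changing the aryl group at this position can move the number well beyond the scatter. The entering group carries no oxygen, so a methoxy group is not required for the lower number seen with compound 4, and no measurement given here accounts for the size of the step.

The change removes a methoxy group and adds two methyl groups at once, so the part played by each remains unresolved. Also open, as far as these compounds go, is how a phenyl ring bearing a single methyl group, a chlorine or an amine would compare with compound 4.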